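Notes on a methyl-to-hydrogen change in two cores

This account rests on a few compounds, and the source may have more. Where it says the series, first, only, none or still open, it means among the compounds named here.

Measured so far:
compound 1 `Cc1cccc(/C(N)=N/NC(=S)N2CCSCC2)n1`: > 100000 nM
compound 2 `Cc1ccnc(/C(N)=N/NC(=S)N2CCN(c3ccccn3)CC2)c1`: 12300 nM
compound 3 `N/C(=N\NC(=S)N1CCSCC1)c1ccccn1`: 8800 nM

In a functional assay on MCF7 cells (Homo sapiens) for cytotoxicity, read by MTT assay, with a stated time of 72 h (on this read-out higher numbers stand for weaker inhibition and lower numbers for stronger inhibition), compound 1 gives only a limit, > 100000 nM. Compound 3 gives 8800 nM, and the step from compound 1 to compound 3 is an at least 11-fold lower number from compound 1 to compound 3 (1.05 log units; beyond the scatter), with hydrogen in place of methyl on an aromatic carbon. The difference between the cores of compound 1 and compound 2 is not broken down here. Compound 2 gives 12300 nM; set beside compound 3, the two values lie within the scatter. Compound 4 `N/C(=N\NC(=S)N1CCN(c2ccccn2)CC1)c1ccccn1` is not yet measured. Its change from compound 2 is hydrogen in place of methyl on an aromatic carbon, the same kind of change as from compound 1 to compound 3, though the place differs: there the methyl sits next to the ring nitrogen, here opposite the ring nitrogen. Resting on an at least 11-fold lower number from compound 1 to compound 3 (1.05 log units; beyond the scatter) and on (the limit of > 100000 nM in this assay, at which 1 of the 3 values shown sits), which shows that step to start from a limit, a smaller step is expected from compound 2 to compound 4, a 2.5-fold lower number from compound 2 to compound 4 (0.39 log units; beyond the scatter). Compound 4 is expected to give 5000 nM, between 1500 nM and 15000 nM.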

Compound 4, half-maximal inhibitory concentration: 13700 nM
For compound 4 the middle estimate is 2.7-fold (0.44 log units) below the measured one; low and high end bracket the measured number.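

In this assay, hydrogen in place of methyl gives a 1.1-fold higher number from compound 2 to compound 4 (0.05 log units; within the scatter), so the change does not carry from one core to the other with the same size: the same change on two cores in this assay, an at least 11-fold lower number (1.05 log units; beyond the scatter) from compound 1 to compound 3 and a 1.1-fold higher number (0.05 log units; within the scatter) from compound 2 to compound 4, at least 12-fold (1.10 log units) apart, beyond the scatter of two such steps
The value of compound 1 is a limit and not a number, so the size of the earlier step stays open: the limit of > 100000 nM in this assay, at which 1 of the 4 values shown sits.
The two steps differ in the place of the methyl as well as in the core, so the compounds shown do not tell which of the two separates them.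

From the compounds shown here alone, only methyl and hydrogen appear on this ring, so an amine, a methoxy group or a longer chain there remains open. Also open, going by these compounds, is a methyl opposite the ring nitrogen on the core of compound 3.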